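Series notes: aryl exchange and antiproliferative limits

This account rests on a few compounds, and the source may have more. Where it says the series, first, only, none or still open, it means among the compounds named here.

Compound 1 `COc1cccc(CNc2ncnc3c2ncn3[C@@H]2O[C@H](CO)[C@@H](O)[C@H]2O)c1` is the reference point, measured in a functional assay on MCF cells (Homo sapiens) for antiproliferative activity, with a stated time of 72 h; on this read-out higher numbers stand for weaker inhibition and lower numbers for stronger inhibition. In this assay compound 1 reaches only the assay limit, > 166000 nM. Compound 2 `OC[C@H]1O[C@@H](n2cnc3c(NCc4cc(O)cc(O)c4)ncnc32)[C@H](O)[C@@H]1O` in this assay likewise gives only a limit, > 166000 nM. Compound 3 `COc1cc(CNc2ncnc3c2ncn3[C@@H]2O[C@H](CO)[C@@H](O)[C@H]2O)cc(OC)c1O` in this assay also sits at a limit, > 166000 nM. Compound 1 thus stands with the other two, all three resting at the limit of > 166000 nM in this assay, at which 3 of the 3 values shown sit. Among the measured compounds shown here, the only one-place step, a step that the two limits leave unreadable from compound 1 to compound 2, cannot be read from two limits. Compound 4 `OC[C@H]1O[C@@H](n2cnc3c(NCc4ccccc4OC(F)F)ncnc32)[C@H](O)[C@@H]1O` differs from compound 1 by 2-(difluoromethoxy)phenyl in place of 3-methoxyphenyl on a saturated chain carbon bound to a nitrogen on an aromatic ring. No readable step bears on this change, so no shift beyond the scatter is expected, and compound 4 is expected to remain at or near the limit. The estimate for compound 4 is 200000 nM, with a range from 100000 nM to 500000 nM. This estimate means an expected step that the limit leaves unreadable from compound 1 to compound 4.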

Compound 4, half-maximal inhibitory concentration: > 166000 nM
Compound 4: only a limit was reported; the forecaster's own chance of this, stated with the estimate: 85%; the middle value does not contradict the limit.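

In this assay compound 4 gives only a limit, > 166000 nM, so no new step can be read between it and compound 1 or compound 2. The compounds shown leave open whether any aryl exchange on the shared core gives a readable value: the limit of > 166000 nM in this assay, at which 4 of the 4 values shown sit.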